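The source may report more compounds than this note shows. Statements on the series, on what has been measured and on what is new or still open speak of the compounds shown alone.

In a functional assay on XF498 cells (Homo sapiens) for inhibition, with a stated time of 72 h (on this read-out lower numbers stand for stronger inhibition and higher numbers for weaker inhibition), compound 3, `CCCC1(CCc2ccccc2)CC(=O)C(C2CC(c3ccc(-c4ccc(Br)cc4)cc3)Cc3ccccc32)=C(O)O1`, gives only a limit, > 10000 nM. Compound 1, `CC1(c2ccccc2)CC(=O)C(C2CC(c3ccc(OCc4ccc(C(F)(F)F)cc4)cc3)Cc3ccccc32)=C(O)O1`, likewise reaches only a limit in this assay, > 10000 nM. Compound 2, `CCC1(c2ccccc2)CC(=O)C(C2CC(c3ccc(OCc4ccc(C(F)(F)F)cc4)cc3)Cc3ccccc32)=C(O)O1`, also stops at a limit, > 10000 nM. Within the data shown here, the single step between measured compounds, a step that the two limits leave unreadable from compound 1 to compound 2, therefore cannot be read. Compound 4, `CCCC1(CCc2ccccc2)CC(=O)C(C2CC(c3ccc(OCc4ccc(C(F)(F)F)cc4)cc3)Cc3ccccc32)=C(O)O1`, differs from compound 3 in one place: (4-(trifluoromethyl)benzyl)oxy in place of 4-bromophenyl on an aromatic carbon. After this change compound 4 carries the same group as compounds 1 and 2, which both sit at the limit of > 10000 nM in this assay, at which 3 of the 3 values shown sit, as does compound 3. Among the measured compounds shown here, no measured step bears on this exact change, so the expectation rests only on all three measured compounds sitting at the limit. The expected step is a step that the limit leaves unreadable from compound 3 to compound 4. Compound 4 is thus expected to give 20000 nM, between 5000 nM and 100000 nM, most likely once more only a limit.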

Compound 4, half-maximal inhibitory concentration: > 10000 nM
Compound 4: no number, only a limit; the forecaster's own chance of this, stated with the estimate: 85%; the middle value does not contradict the limit.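

The step between compound 3 and compound 4 cannot be read, because both compounds give only a limit: the limit of > 10000 nM in this assay, at which 4 of the 4 values shown sit.

The compounds shown leave open what structure, if any, would give an actual number in this assay.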